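Propanoyl to propylcarbonyl: compound 3 to compound 4

A few compounds are considered here, and "the series" means these few. Any claim that something is new, unique, unknown or untested is made for them only; others in the source may bear on it.

In a functional assay on PC-3 cells (Homo sapiens) for antiproliferative activity, read by MTT assay, with a stated time of 72 h (on this read-out lower numbers stand for stronger inhibition and higher numbers for weaker inhibition), compound 3 (`CCC(=O)NNC(=O)c1csc2ncc(-c3ccc(Br)cc3)n12`) gives 43700 nM, the middle of the three numbers available. Compound 1 (`CCCC(=O)NNC(=O)c1csc2ncc(-c3ccc(OC)cc3)n12`) gives 66400 nM, which lies within the scatter of compound 3. Compound 2 (`CC(=O)NNC(=O)c1csc2ncc(-c3ccc(Br)cc3)n12`) gives 12700 nM, a clearly lower number than compound 3 and so stronger inhibition.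

Compound 4 (`CCCC(=O)NNC(=O)c1csc2ncc(-c3ccc(Br)cc3)n12`) differs from compound 3 by methyl in place of hydrogen on a saturated chain carbon, two bonds along the chain from a carbonyl carbon. This is methyl in place of hydrogen on a saturated chain carbon, two bonds along the chain from a carbonyl carbon, and it turns propanoyl to propylcarbonyl.

Among the compounds with values here, one measured step bears on this change: a 3.4-fold higher number from compound 2 to compound 3 (0.54 log units; beyond the scatter), a modest rise beyond the scatter, with methyl in place of hydrogen on a saturated chain carbon bound to a carbonyl carbon. That step sits one carbon closer to the carbonyl, and a single step cannot establish a trend. Within the data shown here, compound 1 has no measured step to either neighbour, so it offers no direct comparison.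

A smaller move in the same direction is therefore expected in this assay, most likely not beyond the scatter. The expected change is a 1.3-fold higher number from compound 3 to compound 4 (0.10 log units; within the scatter). For compound 4 the estimated value is 55000 nM, with an expected range of 25000 nM to 120000 nM.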

Compound 4, half-maximal inhibitory concentration: 58500 nM
The estimate for compound 4 lay 1.1-fold (0.03 log units) below the measured number; measured number inside the range.
By their numbers in this assay, from the lowest: compound 2; then compounds 3, 4 and 1 (each within the scatter of the next).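

Chain notes: in this assay, methyl in place of hydrogen on a saturated chain carbon, two bonds along the chain from a carbonyl carbon, gives a 1.3-fold higher number from compound 3 to compound 4 (0.13 log units; within the scatter), so this change stays within the scatter, unlike the step one carbon closer to the carbonyl, while the two chain steps taken together give a 4.6-fold higher number from compound 2 to compound 4 (0.66 log units; beyond the scatter). Among the three bromo compounds, the separation beyond the scatter therefore sets compound 2 apart from compound 3 and compound 4, and compound 4 adds no further separation at the end of the chain. Within the data shown here, the new compound also gives the first direct reading of the aromatic substituent, with bromo in place of methoxy on an aromatic carbon at a 1.1-fold lower number from compound 1 to compound 4 (0.06 log units; within the scatter), which is within the scatter on this one chain. No measurement at hand gives a reason for any of these numbers.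

As far as these compounds go, whether a longer chain such as pentanoyl stays within the scatter of compound 4, or whether an amine or a carboxylic acid at the chain end moves the number, remains open. Also open, from the compounds shown here alone, is whether bromo and methoxy stay within the scatter of each other on a shorter chain.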